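The compounds below may be only part of what the source reports. "The series", "measured", "known", "first", "only" and "open" are said of these compounds alone.

Three compounds share one core and differ only in the aromatic group attached to one carbon of that core. Compound 1 `CC(C)(C)Cc1c(-c2ccoc2)sc(N)c1C(=O)c1ccc(Cl)cc1` carries a furan-3-yl group at that position, compound 2 `Cc1cccc(-c2sc(N)c(C(=O)c3ccc(Cl)cc3)c2CC(C)(C)C)c1` a 3-methylphenyl group, and compound 3 `Cc1ccccc1-c1sc(N)c(C(=O)c2ccc(Cl)cc2)c1CC(C)(C)C` a 2-methylphenyl group. In an assay on CHO cells for displacement of a labelled ligand from adenosine receptor A3 (Homo sapiens), read by scintillation counting, tested at 10 uM (on this read-out lower numbers stand for less inhibition and higher numbers for more inhibition at the one concentration tested (going by the name of the read-out)), compound 1 gives 1%. In this assay compound 2 gives 1%. In this assay compound 3 gives 1%. The three steps that connect them, no change at the digits printed from compound 1 to compound 2 (within the scatter), no change at the digits printed from compound 1 to compound 3 (within the scatter) and no change at the digits printed from compound 2 to compound 3 (within the scatter), all stay within the scatter, so compound 3 stands level with compounds 1 and 2, and none of the three can be called stronger or weaker than the others.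

Compound 4 `CC(C)(C)Cc1c(-c2cccs2)sc(N)c1C(=O)c1ccc(Cl)cc1` has not yet been measured. The change from compound 3 is thiophen-2-yl in place of 2-methylphenyl on an aromatic carbon. Among the compounds with values here, every measured step so far replaced one aromatic group with another at this same carbon, and every one of them left the read-out unchanged. The step from compound 3 to compound 4 is the same kind of exchange, so the expected step of a number 1 percentage points higher from compound 3 to compound 4 (within the scatter) is none beyond the scatter. Compound 4 is therefore estimated to give 2% in this assay, with an expected range from -8% to 12%.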

Compound 4, a percentage reported as inhibition, at one concentration (the size of the read-out at that concentration, not a potency): 1%
Estimate against measurement, compound 4: 1 percentage points above, and the stated range covers the measured number.
By their numbers in this assay, from the lowest: compounds 1, 2, 3 and 4 (each within the scatter of the next).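

In this assay, placing thiophen-2-yl on this carbon gives no change at the digits printed from compound 3 to compound 4 (within the scatter) and no change at the digits printed from compound 2 to compound 4 (within the scatter) and also no change at the digits printed from compound 1 to compound 4 (within the scatter). A five-membered aromatic ring with sulfur therefore joins furan-3-yl, 3-methylphenyl and 2-methylphenyl, so all four aromatic groups on the shared core read alike here, whether the ring is six-membered and of carbon only or five-membered with a hetero atom. Nothing available explains this flat result.

Still open, on these data alone, is whether a non-aromatic group at this carbon, such as an amine, a carboxylic acid or a longer alkyl chain, would move the reading, and whether changing the neopentyl group or the (4-chlorophenyl)carbonyl group would do so. All four compounds show very little inhibition at the one concentration tested, so these numbers cannot reveal any difference in potency among them, and they do not show which parts of the core matter for this receptor.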